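Swapping a Hydroxyl Tail for Isobutyl on Two Cores

A few compounds are considered here, and "the series" means these few. Any claim that something is new, unique, unknown or untested is made for them only; others in the source may bear on it.

Of the compounds shown here, three have been tested in an assay for inhibition of serine/threonine-protein kinase PLK2 (Homo sapiens), read by FRET and Z'-LYTE, with a stated time of 1 h; on this read-out lower numbers stand for stronger inhibition and higher numbers for weaker inhibition. Compound 2 `CCC1C(=O)N(C)c2cnc(Nc3ccc(S(=O)(=O)NCCO)cc3)nc2N1c1ccn(C)n1` gives 478 nM in this assay, and compound 1 `CCC1C(=O)N(C)c2cnc(Nc3ccc(S(=O)(=O)NCC(C)C)cc3)nc2N1c1ccn(C)n1` gives 311 nM. The two differ by isopropyl in place of hydroxymethyl on a saturated chain carbon bound to a sulfonamide nitrogen, and that change produced a 1.5-fold lower number from compound 2 to compound 1 (0.19 log units; within the scatter). Compound 3 `CC[C@@H]1C(=O)N(C)c2cnc(Nc3ccc(S(=O)(=O)NCCO)cc3)nc2N1C1CCCC1` has a different core; how its core differs from that of compound 2 is not broken down here. In this assay compound 3 gives 7.86 nM, a number far lower than those of compound 1 and compound 2, a gap told as lying beyond the usual scatter.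

Compound 4 `CC[C@@H]1C(=O)N(C)c2cnc(Nc3ccc(S(=O)(=O)NCC(C)C)cc3)nc2N1C1CCCC1` has not yet been measured. Going by the values given here, it differs from compound 3 by isopropyl in place of hydroxymethyl on a saturated chain carbon bound to a sulfonamide nitrogen, the same change at the same place as the one made from compound 2 to compound 1. Because that earlier change produced a 1.5-fold lower number from compound 2 to compound 1 (0.19 log units; within the scatter), a small step is expected again here. The expected step for compound 4 is a 1.3-fold lower number from compound 3 to compound 4 (0.12 log units; within the scatter), resting on the assumption that the change behaves alike on the core of compound 3. Compound 4 is therefore estimated to give 6 nM in this assay, with a likely range from 2.5 nM to 15 nM.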

Compound 4, half-maximal inhibitory concentration: 21.8 nM
Beside the measured number, compound 4's estimate is 3.6-fold (0.56 log units) below it, outside the stated range (above it).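

In this assay, putting isobutyl in place of 2-hydroxyethyl on the core of compound 3 gave a 2.8-fold higher number from compound 3 to compound 4 (0.44 log units; beyond the scatter), and this step does not match the one seen on the other core: the same change on two cores in this assay, a 1.5-fold lower number (0.19 log units; within the scatter) from compound 2 to compound 1 and a 2.8-fold higher number (0.44 log units; beyond the scatter) from compound 3 to compound 4, 4.3-fold (0.63 log units) apart, beyond the scatter of two such steps. The same change therefore cannot be carried from one core to the other in this series with its size assumed to stay the same: its step stays within the scatter on the core of compound 2 but goes beyond it on the core of compound 3. Going by these compounds alone, this rests on only one pair of compounds per core, so it does not show which feature of the cores sets the two steps apart, or how the change would behave on a third core.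

The compounds shown leave open whether other tails on the sulfonamide nitrogen, such as a chain ending in an amine or a carboxylic acid, or a longer chain ending in a hydroxyl, would also differ between the two cores. They also leave open how much of the gap between the two steps would remain in repeated measurements.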